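The compounds below may be only part of what the source reports. "The series", "measured", "known", "first", "only" and "open" are said of these compounds alone.

Working notes on the series.

Compound 1 `O=C(O)[C@H]1NC[C@H](O)[C@H](O)[C@H]1O` and compound 2 `O=C(O)[C@@H]1NC[C@@H](O)[C@@H](O)[C@H]1O` share every atom and bond and differ only in how three ring stereocentres are drawn. Going by the values given here, in an assay for inhibition of alpha-N-acetylgalactosaminidase (Gallus gallus), tested at 1000 uM (a higher number here means more inhibition at the concentration tested (going by the name of the read-out), a lower number less inhibition), compound 1 gives 21%, and compound 2 gives 8.2%; the step of a number 12.8 percentage points lower from compound 1 to compound 2 (beyond the scatter) is the only measured comparison. Compound 2 stands lowest of the two numbers, with compound 1 its nearest neighbour above it. The only thing separating the two is the fact that compounds 1 and 2 differ only in the configuration as drawn, so the drop is tied to the drawn configuration and to nothing else.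

Compound 3 `O=C(O)[C@H]1NC[C@H](O)[C@@H](O)[C@H]1O` is the next diastereomer. Compared with compound 2, (the two compounds have the same atoms and bonds and differ only in configuration as drawn: 2 of 4 stereo elements differ; a stereocentre at a saturated ring carbon is drawn R in compound 2 and S in compound 3; a stereocentre at a saturated ring carbon is drawn R in compound 2 and S in compound 3). Among the compounds with values here, the step from compound 1 to compound 2 is the single measured step that bears on this change; it was modest, just beyond the scatter, and flipping two of the three centres back toward the arrangement of compound 1 suggests a step in this assay that is expected to be small, if anything upward, and possibly within the scatter. The expected step from compound 2 to compound 3 is a number 6.8 percentage points higher from compound 2 to compound 3 (within the scatter). Compound 3 is therefore estimated at 15%, in the range 3% to 32%.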

Compound 3, a percentage reported as inhibition, at one concentration (the size of the read-out at that concentration, not a potency): 31%
Estimate against measurement, compound 3: 16 percentage points below; the measured number falls inside the stated range.
By their numbers in this assay, from the lowest: compound 2; then compounds 1 and 3 (each within the scatter of the next).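

Changing two drawn stereocentres is enough to separate compound 3 from compound 2 in this assay, with the step of a number 22.8 percentage points higher from compound 2 to compound 3 (beyond the scatter): the fact that compounds 2 and 3 differ only in the configuration as drawn

The one centre that separates compound 1 from compound 3 gives the step of a number 10 percentage points higher from compound 1 to compound 3 (within the scatter), so changing this centre alone does not resolve the two compounds in this read-out, and the low number of compound 2 goes with the two further centres in which it differs from both: the fact that compounds 1 and 3 differ only in the configuration as drawn

Compound 2 is now the lowest of the three, with its steps to compound 1 and to compound 3 both beyond the scatter, although all three numbers are single readings at one concentration and not potencies.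

Whether one of the two centres separating compound 2 from compound 3 carries the step by itself stays open, since no compound shown changes either of them alone. All three compounds also keep the same carboxylic acid and the same free amine, so the series says nothing yet about a methyl ester or a primary amide in place of the acid, or a longer chain on the amine.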